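Changing the aryl group on a permeability scaffold

A few compounds are considered here, and "the series" means these few. Any claim that something is new, unique, unknown or untested is made for them only; others in the source may bear on it.

Measured compounds:
- Compound 1, `Cc1cc(C)c(-c2nc(CN3CCC(C(=O)NCCCN4C[C@H](C)C[C@H](C)C4)CC3)c(C)o2)c(C)c1`: "not determined" (no result reported) in a physicochemical assay for permeability, using PAMPA; on this read-out lower numbers stand for lower permeability and higher numbers for higher permeability
- Compound 2, `Cc1ccccc1-c1nc(CN2CCC(C(=O)NCCCN3CC(C)(C)CC(C)(C)C3)CC2)c(C)o1`: > 1390 10^-6 cm/s
- Compound 3, `Cc1ccccc1-c1nc(CN2CCC(C(=O)NCCCN3CCCCC3)CC2)c(C)o1`: 34.5 10^-6 cm/s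

Compound 1 has no number of its own in this assay, so it cannot be placed among the others. For compound 2 the value is a limit of this assay, not a number, and it is the only one of the three that sits at the limit of > 1390 10^-6 cm/s in this assay, at which 1 of the 3 values shown sits. Among the compounds with values here, the one measured step, an at least 40-fold lower number from compound 2 to compound 3 (1.60 log units; beyond the scatter), concerns the saturated ring at the far end of the chain and is large. It does not touch the part that changes here.

Compound 4, `COc1cccc(Br)c1-c1nc(CN2CCC(C(=O)NCCCN3C[C@H](C)C[C@H](C)C3)CC2)c(C)o1`, differs from compound 1 in one place: 2-bromo-6-methoxyphenyl in place of 2,4,6-trimethylphenyl on an aromatic carbon. No measured step covers an exchange on that aromatic carbon, so no direction can be read from the steps shown. The remaining parts of compound 4 lie between those of compound 2 and compound 3 in size, and the estimate for compound 4 in this assay is expected to be 250 10^-6 cm/s, with a range from 60 10^-6 cm/s to 1000 10^-6 cm/s.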

Compound 4, apparent permeability: 245 10^-6 cm/s
Compound 4: the middle estimate sits 1.0-fold (0.01 log units) above what was measured; the range from low to high includes it.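

No new step can be read: compound 4 differs from compound 1 in one place, but compound 1 gives no number in this assay to compare with. Nothing shown offers a reason for the value of compound 4. The compounds shown leave open how 2-bromo-6-methoxyphenyl in place of 2,4,6-trimethylphenyl shifts this read-out.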